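Swapping the Aromatic Group on the Ring Nitrogen

The source may hold more compounds than are shown below. What is called first, only, known or untested is meant among the compounds shown, and "the series" means these compounds.

Of the compounds shown here, two sharing one core have been measured in a functional assay on SJSA-1 cells (Homo sapiens) for inhibition, read by CCK-8 assay, with a stated time of 72 h, tested at 1 uM; a lower number here means less inhibition, a higher number more inhibition at the concentration tested (going by the name of the read-out). Compound 1 `CCN1C(=O)CSC1c1cccc(C(=O)NCCCCc2ccccc2)c1` gives 3%. Compound 2 `CC(F)(F)c1cccc(N2C(=O)CSC2c2cccc(C(=O)NCCCCc3ccccc3)c2)c1` gives 68%, the higher of the two numbers, and the step of a number 65 percentage points higher from compound 1 to compound 2 (beyond the scatter) is large. Compound 3 `COc1ccc(N2C(=O)CSC2c2cccc(C(=O)NCCCCc3ccccc3)c2)c(OC)c1` has not yet been measured; it differs from compound 2 by a group of 10 heavy atoms (8 carbon, 2 oxygen; one six-membered aromatic ring of carbon only) in place of a group of 10 heavy atoms (8 carbon, 2 fluorine; one six-membered aromatic ring of carbon only), on an amide-type nitrogen in a ring. Among the compounds with values here, the only measured step, from compound 1 to compound 2, touched the same position, but there a short chain was exchanged for an aromatic group, whereas here one aromatic group replaces another. Within the data shown here, no measured pair shows such an exchange, so the direction of the coming step cannot be read from the data and the uncertainty is wide. Because the step of a number 65 percentage points higher from compound 1 to compound 2 (beyond the scatter) came with an aromatic group entering this position, and compound 3 keeps an aromatic group there, compound 3 is expected to retain much of the inhibition, with a moderate downward step a number 18 percentage points lower from compound 2 to compound 3 (beyond the scatter) estimated. Compound 3 is thus estimated at 50%, within a range from 15% to 80%.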

Compound 3, a percentage reported as inhibition, at one concentration (the size of the read-out at that concentration, not a potency): 85%
The estimate for compound 3 lay 35 percentage points below the measured number; the measured number lies above the stated range.
By their numbers in this assay, from the lowest: compound 1; then compound 2; then compound 3.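

At this position the identity of the aromatic group matters, not only its presence: in this assay, 2,4-dimethoxyphenyl on the amide-type nitrogen gives a number 17 percentage points higher from compound 2 to compound 3 (beyond the scatter), a step beyond the scatter between two groups of equal heavy-atom count, each with one six-membered aromatic ring of carbon only. The same group in place of ethyl gives a number 82 percentage points higher from compound 1 to compound 3 (beyond the scatter), so both aromatic groups now stand well clear of the ethyl compound. The entering group counts two hydrogen-bond acceptors and the leaving group none, but no measurement available here explains the gain.

The compounds shown leave open whether both methoxy groups are needed, and how a plain phenyl ring or a phenyl ring with a single methoxy group would read at this position. They also leave open how a hydroxyl group or an amine on the ring would compare.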